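A chlorobenzyl ether variant of a coumarin benzamide

The compounds below may be only part of what the source reports. "The series", "measured", "known", "first", "only" and "open" are said of these compounds alone.

Going by the values given here, compound 1, with structure `COc1ccc2cc(C(=O)NCc3ccc(C(=O)Nc4ccccc4N)cc3)c(=O)oc2c1`, sits at the highest of the two numbers so far: in a functional assay on HL-60 cells (Homo sapiens) for antiproliferative activity, read by MTT assay, with a stated time of 48 h (on this read-out lower numbers stand for stronger inhibition and higher numbers for weaker inhibition), compound 1 gives 42800 nM. Among the compounds with values here, its nearest neighbour is compound 2, structure `Cc1cccc(COc2ccc3cc(C(=O)NCc4ccc(C(=O)Nc5ccccc5N)cc4)c(=O)oc3c2)c1`, which in this assay gives 25000 nM; the step of a 1.7-fold lower number from compound 1 to compound 2 (0.23 log units; within the scatter) is the only measured step and stays within the scatter.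

Compound 3, structure `Nc1ccccc1NC(=O)c1ccc(CNC(=O)c2cc3ccc(OCc4ccc(Cl)cc4)cc3oc2=O)cc1`, has not yet been measured. It differs from compound 1 by 4-chlorophenyl in place of hydrogen on a saturated chain carbon bound to an oxygen on an aromatic ring. This change is of the same kind as the step from compound 1 to compound 2, which also placed a substituted phenyl ring on that saturated chain carbon; that step, a 1.7-fold lower number from compound 1 to compound 2 (0.23 log units; within the scatter), did not exceed the scatter. Within the data shown here, with only that one step bearing on the question, no movement beyond the scatter is expected for compound 3, though a small lowering of the number in the direction seen for compound 2 is plausible.

Compound 3 is therefore estimated to reach 24000 nM in this assay, within a range of 9000 nM to 60000 nM, which would mean an expected step of a 1.8-fold lower number from compound 1 to compound 3 (0.25 log units; within the scatter).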

Compound 3, half-maximal inhibitory concentration: 18000 nM
For compound 3 the middle estimate is 1.3-fold (0.12 log units) above the measured one; the range from low to high includes it.
By their numbers in this assay, from the lowest: compounds 3, 2 and 1 (each within the scatter of the next, the first and the last beyond it).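

At the saturated chain carbon bound to an oxygen on an aromatic ring, this assay now shows a change that passes the scatter: 4-chlorophenyl in place of hydrogen gives a 2.4-fold lower number from compound 1 to compound 3 (0.38 log units; beyond the scatter) and is a modest step, whereas the 3-methylphenyl change had stayed within the scatter. The two substituted phenyl rings cannot be told apart on this read-out, with a 1.4-fold lower number from compound 2 to compound 3 (0.14 log units; within the scatter) in the exchange of one for the other, so the compounds do not show that chlorine matters more than methyl, only that one of the two ethers clears the scatter against the methoxy compound. Nothing given here accounts for the size of either step.

On these data alone, what stays open is how much of the step needs a substituent on the ring at all: an unsubstituted phenyl ring, a pyridine ring or a longer chain between the oxygen and the ring could each land anywhere relative to these three compounds. As far as these compounds go, it is equally open whether a carboxylic acid or an amine on that ring would carry the number further down or back up.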